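From an Amide Chain to a Substituted Phenyl Urea

This account rests on a few compounds, and the source may have more. Where it says the series, first, only, none or still open, it means among the compounds named here.

Compound 1 `O=C(CCc1cccc(C(F)(F)F)c1)Nc1cc(Oc2ccc3nc(NC(=O)C4CC4)sc3c2)ccc1F` is the weakest binder among the three measured compounds: in an assay for binding affinity to receptor-interacting serine/threonine-protein kinase 3 (Homo sapiens), read by KINOMEscan and polymerase chain reaction, with a stated time of 1 h (on this read-out higher numbers stand for weaker binding and lower numbers for tighter binding), compound 1 gives 790 nM. Its nearest neighbour is compound 2 `CCOC(=O)c1cccc(NC(=O)Nc2cc(Oc3ccc4nc(NC(=O)C5CC5)sc4c3)ccc2F)c1`, which in this assay gives 72 nM, the step being an 11-fold lower number from compound 1 to compound 2 (1.04 log units; beyond the scatter). Compound 3 `COc1cccc(NC(=O)Nc2cc(Oc3ccc4nc(NC(=O)C5CC5)sc4c3)ccc2F)c1` lies furthest off, with 69 nM in this assay, a step of an 11-fold lower number from compound 1 to compound 3 (1.06 log units; beyond the scatter). Between compound 2 and compound 3 the difference is a 1.0-fold lower number from compound 2 to compound 3 (0.02 log units; within the scatter).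

Compound 4 `CC(=O)c1cccc(NC(=O)Nc2cc(Oc3ccc4nc(NC(=O)C5CC5)sc4c3)ccc2F)c1` has not yet been measured. It differs from compound 1 in one place: (3-acetylphenyl)amino in place of 2-(3-(trifluoromethyl)phenyl)ethyl on a carbonyl carbon. Both measured steps from compound 1 exchange the same 2-(3-(trifluoromethyl)phenyl)ethyl for a substituted phenylamino group, and both were large and in the same direction; the exchange of the substituent on the aromatic carbon between compound 2 and compound 3 changed nothing beyond the scatter. A step of similar size and direction is therefore expected, about an 11-fold lower number from compound 1 to compound 4 (1.05 log units; beyond the scatter). Compound 4 is accordingly estimated at 70 nM in this assay, with a range from 30 nM to 170 nM.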

Compound 4, dissociation constant: 53 nM
The estimate for compound 4 lay 1.3-fold (0.12 log units) above the measured number; measured number inside the range.
By their numbers in this assay, from the lowest: compounds 4, 3 and 2 (each within the scatter of the next); then compound 1.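

With (3-acetylphenyl)amino on this carbonyl carbon, this assay shows the same large step a third time: a 15-fold lower number from compound 1 to compound 4 (1.17 log units; beyond the scatter). The substituent on the phenyl ring can now be ethoxycarbonyl, methoxy or acetyl with every difference staying within the scatter, as a 1.3-fold lower number from compound 3 to compound 4 (0.11 log units; within the scatter) and a 1.4-fold lower number from compound 2 to compound 4 (0.13 log units; within the scatter) show. Across compound 2, compound 3 and compound 4, the large step therefore goes with the exchange on the carbonyl carbon, and none of these three substituents sets its compound apart from the other two.

The compounds shown do not separate the entering amino nitrogen from the departing trifluoromethyl group and chain, and they do not show whether a carboxylic acid or an amine in the substituent's place would fit this pattern. The data give no evidence on why this exchange matters so much.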